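This account rests on a few compounds, and the source may have more. Where it says the series, first, only, none or still open, it means among the compounds named here.

Of the compounds shown here, two that share a common core have been tested in a functional assay on SK-MEL-28 cells (Homo sapiens) for inhibition, read by sulforhodamine B assay, with a stated time of 48 h; on this read-out lower numbers stand for stronger inhibition of growth and higher numbers for weaker inhibition of growth. Compound 1, `COc1ccc(-c2cc(/C=C/C(=O)c3ccc(N)cc3)[nH]n2)cc1`, gives 1870 nM in this assay. Compound 2, `COc1cc(-c2cc(/C=C/C(=O)c3ccc(Cl)c(Cl)c3)[nH]n2)cc(OC)c1OC`, gives 18500 nM in this assay, which is the higher of the two numbers; its gap from compound 1 lies beyond the usual scatter of repeated measurements. Compound 3, `COc1ccc(C(=O)/C=C/c2cc(-c3cc(OC)c(OC)c(OC)c3)n[nH]2)cc1`, has not yet been measured. It differs from compound 2 in one place: 4-methoxyphenyl in place of 3,4-dichlorophenyl on a carbonyl carbon. Within the data shown here, no measured pair shows this change on its own, and the two values at hand do not isolate it, since compound 1 and compound 2 differ in more than one place. A modest step toward a lower number is therefore expected, a 2.3-fold lower number from compound 2 to compound 3 (0.36 log units; beyond the scatter), with a result within the scatter also possible. For compound 3 the estimate in this assay is 8000 nM, within a range from 2000 nM to 30000 nM.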

Compound 3, concentration for 50% growth inhibition: 2120 nM
Beside the measured number, compound 3's estimate is 3.8-fold (0.58 log units) above it, and the stated range covers the measured number.
By their numbers in this assay, from the lowest: compounds 1 and 3 (each within the scatter of the next); then compound 2.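

With the rest of the structure held constant, 4-methoxyphenyl in place of 3,4-dichlorophenyl on a carbonyl carbon gives an 8.7-fold lower number from compound 2 to compound 3 (0.94 log units; beyond the scatter) in this assay. Among these compounds, this is the first change in these compounds that can be read on its own, as compound 1 and compound 2 differ in more than one place, and it shows that the read-out is sensitive to the group at this position. No measurement at hand accounts for the size of this step.

The compounds shown leave open whether the step follows from gaining the methoxy group or from losing the two chlorines, a question that an unsubstituted phenyl or a 4-chlorophenyl at this place would help to separate. They also leave open how a carboxylic acid on this ring would read, and whether the same step would appear with another group at the far end of the shared core.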